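Ring-bearing group replaces an acyclic one on the amine nitrogen

The source may hold more compounds than are shown below. What is called first, only, known or untested is meant among the compounds shown, and "the series" means these compounds.

Measured compounds:
compound 1 `CC(C)(C)OC(=O)N1CCC(O[C@H]2CC[C@@H](Oc3ccc(S(C)(=O)=O)cc3)CC2)CC1` — 266 nM
compound 2 `C[C@H](CF)OC(=O)N1CCC(O[C@H]2CC[C@H](Oc3cnc(S(C)(=O)=O)cn3)CC2)CC1` — 36.8 nM

In a functional assay on isolated protein for agonist activity at Glucose-dependent insulinotropic receptor (Homo sapiens), read by HTRF and cAMP accumulation (a higher number here means that more compound is needed for the effect, a lower number that less compound is needed), compound 2 gives 36.8 nM, the lowest of the two numbers; compound 1 gives 266 nM, a gap beyond the scatter. Compound 3 `CS(=O)(=O)c1cnc(O[C@H]2CC[C@H](OC3CCN(CC4(C(F)(F)F)CCC4)CC3)CC2)cn1` differs from compound 2 in one place: a group of 9 heavy atoms (6 carbon, 3 fluorine; one four-membered non-aromatic ring of carbon only) in place of a group of 7 heavy atoms (4 carbon, 2 oxygen, 1 fluorine; no ring), on an amine nitrogen in a ring. Within the data shown here, no measured pair shows this change, so its effect on this assay is unknown from these data. The step of a 1.8-fold higher number from compound 2 to compound 3 (0.25 log units; within the scatter) is expected to be modest, toward a higher number, with wide uncertainty. For compound 3 the estimate is 65 nM, with a range from 15 nM to 280 nM.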

Compound 3, half-maximal effective concentration: 54.8 nM
Beside the measured number, compound 3's estimate is 1.2-fold (0.07 log units) above it, within the range that was stated.
By their numbers in this assay, from the lowest: compounds 2 and 3 (each within the scatter of the next); then compound 1.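

In this assay, the replacement gives a 1.5-fold higher number from compound 2 to compound 3 (0.17 log units; within the scatter), so this amine nitrogen in a ring accepts (1-(trifluoromethyl)cyclobutyl)methyl, which has 0 hydrogen-bond acceptors, in place of an acyclic group with 2, without a difference that can be told from the scatter. No measurement on hand explains this tolerance. The compounds shown leave open whether the trifluoromethyl matters, since no methyl or hydrogen stands in its place on the cyclobutyl ring. They also leave open how a larger cyclopentyl or cyclohexyl ring would fare at this nitrogen.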